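A few compounds are considered here, and "the series" means these few. Any claim that something is new, unique, unknown or untested is made for them only; others in the source may bear on it.

Three compounds share one core and differ only in the group carried on an aromatic nitrogen. Compound 1 `COc1ccc([C@@H]2CC(=O)c3c(O)cc(OCc4cn(Cc5ccc(C)cc5)nn4)cc3O2)cc1O` gives 16800 nM in a functional assay on RAW264.7 cells (Mus musculus) for inhibition, read by Griess assay, with stated times of 2 h and 24 h (on this read-out higher numbers stand for weaker inhibition and lower numbers for stronger inhibition), compound 2 `COc1ccc([C@@H]2CC(=O)c3c(O)cc(OCc4cn(Cc5cccc(Cl)c5)nn4)cc3O2)cc1O` gives 18200 nM, and compound 3 `COc1ccc([C@@H]2CC(=O)c3c(O)cc(OCc4cn(C5CCCCC5)nn4)cc3O2)cc1O` gives 15600 nM, the lowest of the three numbers, although its steps to the other two lie within the scatter. Compound 4 `COc1ccc([C@@H]2CC(=O)c3c(O)cc(OCc4cn(Cc5ccccc5C(F)(F)F)nn4)cc3O2)cc1O` differs from compound 3 by 2-(trifluoromethyl)benzyl in place of cyclohexyl on an aromatic nitrogen. The nearest precedents are the two swaps of a substituted benzyl group for cyclohexyl: a 1.1-fold lower number from compound 1 to compound 3 (0.03 log units; within the scatter) and a 1.2-fold lower number from compound 2 to compound 3 (0.07 log units; within the scatter), both within the scatter. A third benzyl variant is therefore expected to behave alike, so the step of a 1.1-fold higher number from compound 3 to compound 4 (0.04 log units; within the scatter) is expected to stay within the scatter. Compound 4 is estimated at 17000 nM, between 9000 nM and 32000 nM.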

Compound 4, half-maximal inhibitory concentration: 12500 nM
Beside the measured number, compound 4's estimate is 1.4-fold (0.13 log units) above it, and the stated range covers the measured number.
By their numbers in this assay, from the lowest: compounds 4, 3, 1 and 2 (each within the scatter of the next).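

Swapping cyclohexyl, with 6 heavy atoms, for 2-(trifluoromethyl)benzyl, with 11 heavy atoms including fluorine, still leaves the number within the scatter (a 1.2-fold lower number from compound 3 to compound 4 (0.10 log units; within the scatter)). The comparisons with the other two benzyl compounds agree (a 1.3-fold lower number from compound 1 to compound 4 (0.13 log units; within the scatter); a 1.5-fold lower number from compound 2 to compound 4 (0.16 log units; within the scatter)), and the last is the widest gap so far, so all four groups on this aromatic nitrogen read alike. No measurement shown here accounts for these small differences.

As far as these compounds go, whether an amine, a carboxylic acid or a longer chain on this nitrogen would carry the number beyond the scatter remains open.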